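The source may report more compounds than this note shows. Statements on the series, on what has been measured and on what is new or still open speak of the compounds shown alone.

Compound 1 `NC1CCC(Nc2nc(NCc3ccc(-n4cccn4)cc3)c3ncn(C4CCCC4)c3n2)CC1`: 170 nM
Compound 2 `NC1CCC(Nc2nc(NCc3ccc(-c4ccco4)nc3)c3ncn(C4CCCC4)c3n2)CC1`: 30 nM
Compound 3 `NC1CCC(Nc2nc(NCc3ccc(-c4cccs4)nc3)c3ncn(C4CCCC4)c3n2)CC1`: 40 nM

All three values come from a functional assay on HeLa cells (Homo sapiens) for inhibition, with a stated time of 72 h; on this read-out lower numbers stand for stronger inhibition and higher numbers for weaker inhibition. Compound 3 holds the second highest number of the three, and its closest comparison is a 1.3-fold higher number from compound 2 to compound 3 (0.12 log units; within the scatter). Its furthest is a 4.3-fold lower number from compound 1 to compound 3 (0.63 log units; beyond the scatter). Compound 4 `Nc1ccccc1CNc1nc(NC2CCC(N)CC2)nc2c1ncn2C1CCCC1` changes the group on a saturated chain carbon bound to a nitrogen on an aromatic ring: 2-aminophenyl in place of 6-(thiophen-2-yl)pyridin-3-yl on a saturated chain carbon bound to a nitrogen on an aromatic ring. Two measured swaps at this place bear on it, a 5.7-fold lower number from compound 1 to compound 2 (0.75 log units; beyond the scatter) and a 4.3-fold lower number from compound 1 to compound 3 (0.63 log units; beyond the scatter), and both are modest. Within the data shown here, no measured compound carries 2-aminophenyl, so the expectation is loose: a modest step towards a higher number in this assay. The expected step is a 5.5-fold higher number from compound 3 to compound 4 (0.74 log units; beyond the scatter). For compound 4 the estimated value is 220 nM, with an expected range of 60 nM to 800 nM.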

Compound 4, half-maximal inhibitory concentration: 1030 nM
Estimate against measurement, compound 4: 4.7-fold (0.67 log units) below, outside the stated range (above it).
By their numbers in this assay, from the lowest: compounds 2 and 3 (each within the scatter of the next); then compound 1; then compound 4.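

The swap to 2-aminophenyl costs far more against the two pyridine-bearing groups than any earlier step at this place (a 26-fold higher number from compound 3 to compound 4 (1.41 log units; beyond the scatter)) and (a 34-fold higher number from compound 2 to compound 4 (1.54 log units; beyond the scatter)). It also gives a higher number than the 4-(1H-pyrazol-1-yl)phenyl group (a 6.1-fold higher number from compound 1 to compound 4 (0.78 log units; beyond the scatter)), so all three groups with two aromatic rings on a saturated chain carbon bound to a nitrogen on an aromatic ring give lower numbers than this single-ring group. No measurement shown accounts for the loss. On these data alone, whether it follows from losing the second ring or from the amine itself stays open, and a plain phenyl group at this place would separate the two.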